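The source may report more compounds than this note shows. Statements on the series, on what has been measured and on what is new or still open speak of the compounds shown alone.

Compound 1 `COc1cccc(/C=C/C(=O)c2c(OC)cc(OC)cc2OC)c1`: 8700 nM in a functional assay on MDA-MB-231 cells (Homo sapiens) for cytotoxicity, with a stated time of 48 h; a higher number here means a weaker inhibitor, a lower number a stronger inhibitor
Compound 2 `COc1cc(OC)c(C(=O)/C=C/c2ccc(Br)cc2)c(OC)c1`: 11100 nM
Compound 3 `COc1cc(OC)c(C(=O)/C=C/c2ccc([N+](=O)[O-])cc2)c(OC)c1`: 3300 nM

Compound 2 gives the highest of these three numbers; compound 1 is nearest and compound 3 furthest, as the two steps show: a 1.3-fold higher number from compound 1 to compound 2 (0.11 log units; within the scatter) and a 3.4-fold lower number from compound 2 to compound 3 (0.53 log units; beyond the scatter). Compound 4 `COc1cc(OC)c(C(=O)/C=C/c2ccccc2OC)c(OC)c1` has not yet been measured. It differs from compound 2 by 2-methoxyphenyl in place of 4-bromophenyl on a double-bonded chain carbon bound to a double-bonded chain carbon. The closest guide is the step of a 1.3-fold higher number from compound 1 to compound 2 (0.11 log units; within the scatter): there, too, a methoxyphenyl stood against 4-bromophenyl, and the step stayed within the scatter. The step of a 3.4-fold lower number from compound 2 to compound 3 (0.53 log units; beyond the scatter) concerns a different group and says less here. Among the measured compounds shown here, no measured compound carries 2-methoxyphenyl. Because a 1.3-fold higher number from compound 1 to compound 2 (0.11 log units; within the scatter) was within the scatter, only a small step toward a lower number is expected, a 1.3-fold lower number from compound 2 to compound 4 (0.12 log units; within the scatter). Compound 4 is estimated at 8500 nM, with a range from 3000 nM to 22000 nM.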

Compound 4, half-maximal inhibitory concentration: 13000 nM
The estimate for compound 4 lay 1.5-fold (0.18 log units) below the measured number, within the range that was stated.
By their numbers in this assay, from the lowest: compound 3; then compounds 1, 2 and 4 (each within the scatter of the next).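

Placing 2-methoxyphenyl on the double-bonded chain carbon leaves the number within the scatter of 4-bromophenyl (a 1.2-fold higher number from compound 2 to compound 4 (0.07 log units; within the scatter)). Changing 3-methoxyphenyl to 2-methoxyphenyl also stays within it (a 1.5-fold higher number from compound 1 to compound 4 (0.17 log units; within the scatter)), so these compounds show no effect of where the methoxy group sits on this ring. No separate evidence explains this result.

As far as these compounds go, it remains open whether a 4-methoxyphenyl group would behave in the same way. From the compounds shown here alone, it is also open whether a 4-aminophenyl or 4-carboxyphenyl group would move the number beyond the scatter, as the nitro group of compound 3 did.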